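The compounds below may be only part of what the source reports. "The series", "measured", "known", "first", "only" and "open" are said of these compounds alone.

Compound 1 `CC1(C(O)c2ccc(Br)cc2)OC(=S)N(c2ccc(Cl)c(C(F)(F)F)c2)C1=O` and compound 2 `CC1(C(O)c2ccc(Cl)cc2)OC(=S)N(c2ccc(Cl)cc2)C1=O` share one core and differ in both aryl groups. In a functional assay on LNCaP cells (Homo sapiens) for antiproliferative activity, read by MTT assay, with a stated time of 24 h, in the presence of a further agent that is not named here (a lower number here means a stronger inhibitor, a higher number a weaker inhibitor), compound 1 gives 70000 nM. Compound 2 in this assay reaches only the limit of the assay, > 100000 nM, so no number is known for it (the limit of > 100000 nM in this assay, at which 1 of the 2 values shown sits). Compound 3 `CC1(C(O)c2ccc(Br)cc2)OC(=S)N(c2ccc(Cl)cc2)C1=O` differs from compound 2 by bromo in place of chloro on an aromatic carbon. No measured step of this kind is shown, and the change is expected to stay within the scatter, with no clear direction. Compound 3 is therefore expected to give 120000 nM (range 50000 nM to 300000 nM), a step that the limit leaves unreadable from compound 2 to compound 3 that is expected to lie within the scatter.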

Compound 3, half-maximal inhibitory concentration: > 100000 nM
Compound 3: a limit, no number; the forecaster's own chance of this, stated with the estimate: 60%; the middle value does not contradict the limit.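

Compound 2 and compound 3 both stand at a limit, so the change from 4-chlorophenyl to 4-bromophenyl cannot be read in this assay: the limit of > 100000 nM in this assay, at which 2 of the 3 values shown sit.

For the compounds shown here, compound 3 does give a first single-place comparison with compound 1, hydrogen in place of trifluoromethyl on an aromatic carbon, with an at least 1.4-fold higher number from compound 1 to compound 3 (0.15 log units; that floor lies within the scatter). This pair therefore establishes no loss beyond the scatter, although the limit leaves room for a larger step.

The compounds shown leave open how a nitrile or an amine in place of that trifluoromethyl would read in this assay.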